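Chloro for methoxy on a bicyclic imidazole scaffold

The source may hold more compounds than are shown below. What is called first, only, known or untested is meant among the compounds shown, and "the series" means these compounds.

Compound 1 `c1ccc(C2CCc3nc[nH]c3C2)cc1` — > 10000 nM; > 10000 nM; > 10000 nM (3 entries)
Compound 2 `COc1ccc(C2Cc3nccn3C2)cc1` — "not determined" (no result reported)

In a functional assay on CHO cells for agonist activity at Alpha-1B adrenergic receptor (Homo sapiens), read by FLIPR and calcium flux (on this read-out lower numbers stand for an effect already at smaller amounts and higher numbers for an effect only at larger amounts of compound), compound 1 gives > 10000 nM; > 10000 nM; > 10000 nM (3 entries), each entry being a limit of the assay rather than a number. For compound 2 this assay reports "not determined" (no result reported), so no number places it. Compound 3 `Clc1ccc(C2Cc3nccn3C2)cc1` differs from compound 2 by chloro in place of methoxy on an aromatic carbon. For the measured compounds named here, no measured pair shows what this change does, so no step size or direction can be claimed beyond the scatter. Compound 3 is expected at 8000 nM, within 1000 nM to 30000 nM, with a good chance that only a limit is returned.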

Compound 3, half-maximal effective concentration in the Alpha-1B adrenergic receptor assay: > 10000 nM
Compound 3 gave a limit, no number; the forecaster's own chance of this, stated with the estimate: 70%; at least 1.2-fold (0.09 log units) between middle value and limit.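

In the Alpha-1B adrenergic receptor assay compound 3 gives > 10000 nM as a limit of the assay and not a number. For the compounds shown here, no step from compound 2 to compound 3 can be read there. The compounds shown leave open whether chloro in place of methoxy changes this result at all. In a physicochemical assay for lipophilicity, at pH 7.4 (a lower number here means a more polar compound, a higher number a more lipophilic compound), compound 2 gives 2 and compound 3 gives 2.6 on the same read-out.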